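From compound 3 to compound 4: an expected step

The compounds below may be only part of what the source reports. "The series", "measured", "known", "first", "only" and "open" are said of these compounds alone.

Values in a toxicity assay on HEK-293T cells (Homo sapiens) for cytotoxicity, read by MTT assay, with a stated time of 72 h; a higher number here means a weaker inhibitor, a lower number a stronger inhibitor:
compound 1 `O=C1c2c[n+]([O-])c3ccccc3c2C(=O)c2c1c1ccccc1n2Cc1cn([C@H]2O[C@H](CO)[C@@H](O)[C@H]2O)nn1`: 1370 nM
compound 2 `CC1(C)OCC(Cn2cc(Cn3c4c(c5ccccc53)C(=O)c3c[n+]([O-])c5ccccc5c3C4=O)nn2)O1`: 5510 nM
compound 3 `CC1(C)O[C@@H](CO)[C@H](Cn2cc(Cn3c4c(c5ccccc53)C(=O)c3c[n+]([O-])c5ccccc5c3C4=O)nn2)O1`: 120 nM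

Compound 3 has the lowest number of the three, 120 nM, and its gaps to the other two lie beyond the usual scatter. The unmeasured compound 4 `O=C1c2c[n+]([O-])c3ccccc3c2C(=O)c2c1c1ccccc1n2Cc1cn([C@@H]2O[C@H](CO)[C@@H](O)[C@H](O)[C@H]2O)nn1` differs from it in one group, on an aromatic nitrogen of a five-membered aromatic ring with 3 nitrogen: 3,4,5-trihydroxy-6-(hydroxymethyl)oxan-2-yl in place of (5-(hydroxymethyl)-2,2-dimethyl-1,3-dioxolan-4-yl)methyl on an aromatic nitrogen.

Compound 1 is the closest guide, since its 3,4-dihydroxy-5-(hydroxymethyl)oxolan-2-yl group also stands on that nitrogen and resembles the incoming group. Exchanging that group gave an 11-fold lower number from compound 1 to compound 3 (1.06 log units; beyond the scatter), a large step. The other two steps, a 46-fold lower number from compound 2 to compound 3 (1.66 log units; beyond the scatter) and a 4.0-fold higher number from compound 1 to compound 2 (0.60 log units; beyond the scatter), show that changes in this part of the molecule can move the number considerably.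

A large step towards a higher number is therefore expected, and the estimated change is a 12-fold higher number from compound 3 to compound 4 (1.07 log units; beyond the scatter). Among the compounds with values here, no measured compound carries the six-membered ring, so the range stays wide. The estimate for compound 4 is 1400 nM, with an expected range of 350 nM to 5500 nM.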

Compound 4, half-maximal inhibitory concentration: 940 nM
The estimate for compound 4 lay 1.5-fold (0.17 log units) above the measured number; the range from low to high includes it.
By their numbers in this assay, from the lowest: compound 3; then compounds 4 and 1 (each within the scatter of the next); then compound 2.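

In this assay, putting the six-membered 3,4,5-trihydroxy-6-(hydroxymethyl)oxan-2-yl group on the aromatic nitrogen in place of the five-membered 3,4-dihydroxy-5-(hydroxymethyl)oxolan-2-yl group leaves no change that can be told from scatter (a 1.5-fold lower number from compound 1 to compound 4 (0.16 log units; within the scatter)). So, for these two groups, ring size makes no readable difference at this position. The two dioxolane compounds fall on opposite sides of compound 4 (a 7.8-fold higher number from compound 3 to compound 4 (0.89 log units; beyond the scatter); a 5.9-fold lower number from compound 2 to compound 4 (0.77 log units; beyond the scatter)), which shows that swapping a hydroxylated ring for a dioxolane has no single direction here and that the hydroxymethyl on the dioxolane goes with the lowest number.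

Nothing available explains these differences. On these data alone, it remains open how an amine or a carboxylic acid in place of that hydroxymethyl would move the number.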